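A few compounds are considered here, and "the series" means these few. Any claim that something is new, unique, unknown or untested is made for them only; others in the source may bear on it.

Measured so far in a functional assay on the whole organism with Mus musculus as the target, in the rotarod test; on this read-out lower numbers stand for an effect already at smaller amounts and higher numbers for an effect only at larger amounts of compound:
- compound 1 `O=C(/C=C1\CCc2c(F)cc(F)cc21)NC1CC1`: 62 mg/kg
- compound 2 `NC(=O)/C=C1\CCc2cc(F)c(F)cc21`: 82 mg/kg
- compound 3 `O=C(/C=C1\CCc2c(F)ccc(F)c21)NC1CC1`: 2 mg/kg

Compound 2, at 82 mg/kg, stands at the upper end of these numbers. It cannot be told apart from compound 1 at 62 mg/kg, since the two lie within the usual scatter of each other. Compound 3, at 2 mg/kg, lies well beyond that scatter on the lower side, so its effect in this assay appears at a much smaller dose.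

The next compound to test is compound 4 `NC(=O)/C=C1\CCc2cc(F)ccc21`. It differs from compound 2 in one place, with hydrogen in place of fluoro on an aromatic carbon. Among the measured compounds shown here, no measured pair in this small set shows this change on its own, so the data give no direct size for it. The expectation is therefore no step beyond the scatter, in either direction, and the expected 1.0-fold lower number from compound 2 to compound 4 (0.01 log units; within the scatter) reflects that. Compound 3 at 2 mg/kg shows that values in this set can lie far apart, so the expected range is kept wide. For compound 4 the estimated value is 80 mg/kg, with an expected range from 30 mg/kg to 200 mg/kg.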

Compound 4, dose for half-maximal effect: > 100 mg/kg
Compound 4 gave a limit, no number (the forecaster's own chance of this, stated with the estimate: 10%); at least 1.2-fold (0.09 log units) between middle value and limit.
By their numbers in this assay, from the lowest: compound 3; then compounds 1 and 2 (each within the scatter of the next). At a limit, above all of these: compound 4.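

Among the compounds shown here, this is the first time hydrogen in place of fluoro on an aromatic carbon can be read on its own in this assay, with the rest of compound 2 left unchanged. Compound 4 gives > 100 mg/kg, which is a limit of the assay and not a number. The step reads as an at least 1.2-fold higher number from compound 2 to compound 4 (0.08 log units; that floor lies within the scatter), so nothing here points to a lower number when this fluoro, ortho to a fluoro group, gives way to hydrogen, while the true size of the step stays unknown, and the reading is capped by the assay itself: the limit of > 100 mg/kg in this assay, at which 1 of the 4 values shown sits.

The compounds shown leave open how far the number really lies from that of compound 2, and whether another group on this aromatic carbon, such as chloro, methyl or an amine, would read like fluoro or like hydrogen. Also open, from the compounds shown here alone, is what the same change does when a cyclopropyl group sits on the amide nitrogen, as it does in compound 1 and compound 3.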